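The source may hold more compounds than are shown below. What is called first, only, known or untested is meant among the compounds shown, and "the series" means these compounds.

This piece follows four related compounds and asks how one small change to a side ring affects their power to slow the growth of a human leukaemia cell line, measured in a functional assay on HL-60 cells (Homo sapiens) for antiproliferative activity, read by XTT assay, with a stated time of 72 h; on this read-out higher numbers stand for weaker inhibition and lower numbers for stronger inhibition.

Compound 1 `O=c1[nH]cnc2c1c(-c1cccs1)cn2[C@@H]1O[C@H](CO)[C@@H](O)[C@H]1O` carries a thiophen-2-yl group on its core. In this assay compound 1 gives only a limit, > 20000 nM. Compound 2 `O=c1[nH]cnc2c1c(-c1ccsc1)cn2[C@@H]1O[C@H](CO)[C@@H](O)[C@H]1O` differs from compound 1 by one change, (thiophen-3-yl in place of thiophen-2-yl on an aromatic carbon). In this assay compound 2 gives 12000 nM. The measured step is an at least 1.6-fold lower number from compound 1 to compound 2 (0.22 log units; that floor lies within the scatter). Its true size is uncertain because of the limit of > 20000 nM in this assay, at which 2 of the 3 values shown sit.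

Compound 3 `CNc1ncnc2c1c(-c1cccs1)cn2[C@@H]1O[C@H](CO)[C@@H](O)[C@H]1O` bears the same thiophen-2-yl group on a different core; the difference between the two cores is not broken down here. In this assay compound 3 gives only a limit, > 20000 nM.

Compound 4 `CNc1ncnc2c1c(-c1ccsc1)cn2[C@@H]1O[C@H](CO)[C@@H](O)[C@H]1O` has not yet been measured. It differs from compound 3 by thiophen-3-yl in place of thiophen-2-yl on an aromatic carbon, the same change at the same place as between compound 1 and compound 2. The expected step of a number no higher from compound 3 to compound 4 (the limit leaves the size open) is modest, resting on the measured step of an at least 1.6-fold lower number from compound 1 to compound 2 (0.22 log units; that floor lies within the scatter). Since that step begins at a limit and stays within the scatter, there is a real chance that compound 4 also reports only a limit. Compound 4 is expected to give roughly 20000 nM, with a likely range from 8000 nM to 60000 nM.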

Compound 4, half-maximal inhibitory concentration: > 20000 nM
Compound 4: a limit, no number; the forecaster's own chance of this, stated with the estimate: 55%; the middle value lies on the limit itself.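

Compound 3 and compound 4 both give only a limit in this assay, so the step between them cannot be read, and the swap of thiophen-2-yl for thiophen-3-yl shows no measurable size on this core: the limit of > 20000 nM in this assay, at which 3 of the 4 values shown sit.

The compounds shown leave open how far each limit-bound compound lies from that limit, and whether this swap truly changes growth inhibition on either core.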